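This account rests on a few compounds, and the source may have more. Where it says the series, first, only, none or still open, it means among the compounds named here.

Compound 2 `Cc1cccc2ncnc(O/N=C(\C=C\c3ccccn3)/C=C/c3ccccc3OCc3ccccc3Cl)c12` gives 95.7%.
Compound 3 `Cc1cccc2ncnc(O/N=C(\C=C\c3ccccn3)/C=C/c3ccccc3OCc3ccc(Cl)cc3Cl)c12` gives 93.9%.
Compound 1 `Clc1ccc(COc2ccccc2/C=C/C(/C=C/c2ccccn2)=N/Oc2ncnc3cc(Cl)ccc23)c(Cl)c1` gives 91.8%.

These three were tested in a functional assay on SMMC-7721 cells (Homo sapiens) for inhibition, read by MTT assay, with a stated time of 72 h, tested at 10 uM; a higher number here means a stronger effect of the compound at the concentration tested, a lower number a weaker effect. The unmeasured compound 4 `Clc1ccc2c(O/N=C(\C=C\c3ccccn3)/C=C/c3ccccc3OCc3ccccc3Cl)ncnc2c1` differs from compound 2 by 7-chloroquinazolin-4-yl in place of 5-methylquinazolin-4-yl on an oxygen. The same change has already been made once: compound 1 differs from compound 3 by 7-chloroquinazolin-4-yl in place of 5-methylquinazolin-4-yl on an oxygen, and that step was a number 2.1 percentage points lower from compound 3 to compound 1 (within the scatter). The two pairs sit on different cores, and the difference between the cores is hydrogen in place of chloro on an aromatic carbon. Since the place of the change reads the same in both pairs, it is taken as the same change. Compound 4 is therefore expected to land close to compound 2, with an expected step of a number 2.2 percentage points lower from compound 2 to compound 4 (within the scatter). This expectation rests on a number 2.1 percentage points lower from compound 3 to compound 1 (within the scatter) and on the value that compound 2 gives, 95.7%. The estimate for compound 4 is 93.5%, between 86% and 98%.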

Compound 4, a percentage reported as inhibition, at one concentration (the size of the read-out at that concentration, not a potency): 94.5%
Compound 4: the middle estimate sits 1 percentage points below what was measured; low and high end bracket the measured number.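

Putting 7-chloroquinazolin-4-yl in place of 5-methylquinazolin-4-yl on the oxygen gives a number 1.2 percentage points lower from compound 2 to compound 4 (within the scatter) in this assay, and this agrees with the earlier step: the same change on two cores in this assay, a number 2.1 percentage points lower (within the scatter) from compound 3 to compound 1 and a number 1.2 percentage points lower (within the scatter) from compound 2 to compound 4, 0.9 percentage points apart, within the scatter of two such steps. Hydrogen in place of chloro on an aromatic carbon gives a number 2.7 percentage points higher from compound 1 to compound 4 (within the scatter), which also agrees across the two cores: the same change on two cores in this assay, a number 1.8 percentage points lower (within the scatter) from compound 2 to compound 3 and a number 2.7 percentage points lower (within the scatter) from compound 4 to compound 1, 0.9 percentage points apart, within the scatter of two such steps. Among these compounds, with steps this small, the agreement shows only that neither change visibly shifted the read-out on these two cores; it does not show that either change has a real effect of its own, and a single concentration gives no potency.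

From the compounds shown here alone, whether this holds on other cores, or when an amine or a carboxylic acid replaces the chloro of 7-chloroquinazolin-4-yl, stays open.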